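A few compounds are considered here, and "the series" means these few. Any claim that something is new, unique, unknown or untested is made for them only; others in the source may bear on it.

Measured in a functional assay on MCF7 cells (Homo sapiens) for cytotoxicity, read by MTT assay, with a stated time of 24 h, tested at 80 ug/mL; a higher number here means a stronger effect of the compound at the concentration tested, a lower number a weaker effect:

- compound 1 `Cn1c(-c2ccc(NC(=O)CSc3nc4cc(Cl)ccc4o3)cc2)nc(-c2ccccc2)c1-c1ccccc1` gives 69.1%
- compound 2 `Cc1ccc2oc(SCC(=O)Nc3ccc(-c4nc(-c5ccccc5)c(-c5ccccc5)n4C)cc3)nc2c1` gives 65.1%
- compound 3 `Cn1nnnc1SCC(=O)Nc1ccc(-c2nc(-c3ccccc3)c(-c3ccccc3)n2C)cc1` gives 77.7%

On the bare numbers compound 1 stands second highest of the three, but neither neighbour is separated from it by more than the scatter: a number 4 percentage points lower from compound 1 to compound 2 (within the scatter) and a number 8.6 percentage points higher from compound 1 to compound 3 (within the scatter). Among the compounds with values here, only one step in the set is beyond the scatter, a number 12.6 percentage points higher from compound 2 to compound 3 (beyond the scatter), and it is modest.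

Compound 4 `Cn1c(-c2ccc(NC(=O)CSC3=NCCS3)cc2)nc(-c2ccccc2)c1-c1ccccc1` is the next member; against compound 1 the change is a group of 5 heavy atoms (3 carbon, 1 nitrogen, 1 sulfur; one five-membered non-aromatic ring with 2 hetero atoms) in place of a group of 10 heavy atoms (7 carbon, 1 nitrogen, 1 oxygen, 1 chlorine; one five-membered aromatic ring with 2 hetero atoms, one six-membered aromatic ring of carbon only), on a sulfur. The two steps that bear on it are those in which the benzoxazolyl group on the sulfur was replaced by a small five-membered ring, namely a number 8.6 percentage points higher from compound 1 to compound 3 (within the scatter) and a number 12.6 percentage points higher from compound 2 to compound 3 (beyond the scatter). Both point upward, one within the scatter and one modestly beyond it. The group entering here is non-aromatic rather than a tetrazolyl, so a step of comparable size is expected, at most a small gain, possibly none beyond the scatter. Compound 4 is therefore expected to give about 72%, with a range of 58% to 84%. The expected step is a number 2.9 percentage points higher from compound 1 to compound 4 (within the scatter).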

Compound 4, a percentage reported as activity, at one concentration (the size of the read-out at that concentration, not a potency): 70%
For compound 4 the middle estimate is 2 percentage points above the measured one, and the stated range covers the measured number.
By their numbers in this assay, from the lowest: compounds 2, 1, 4 and 3 (each within the scatter of the next, the first and the last beyond it).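

In this assay, a group of 5 heavy atoms with a five-membered non-aromatic ring on the sulfur reads the same, within the scatter, as either benzoxazolyl group of 10 heavy atoms (a number 0.9 percentage points higher from compound 1 to compound 4 (within the scatter); a number 4.9 percentage points higher from compound 2 to compound 4 (within the scatter)). It also stays within the scatter of the 1-methyl-1H-tetrazol-5-yl group (a number 7.7 percentage points lower from compound 3 to compound 4 (within the scatter)), so on this sulfur neither a smaller group nor giving up an aromatic ring produces a step beyond the scatter in these compounds. No evidence is available on why these groups on the sulfur read alike.

From the compounds shown here alone, whether an amine or a carboxylic acid on the sulfur would give a step beyond the scatter remains open. So does the effect of a longer chain in that place.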